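Styryl Linker in Place of a Biaryl on the Shared Core

A few compounds are considered here, and "the series" means these few. Any claim that something is new, unique, unknown or untested is made for them only; others in the source may bear on it.

Measured compounds:
compound 1, `COC(=O)/C=C/c1cccc(N(Cc2ccc(-c3ccc(C)cc3)cc2)C(=O)C(C)C)c1`, 118 nM
compound 2, `COC(=O)/C=C/c1cccc(N(Cc2ccc(-c3cc(Cl)ccc3OC)cc2)C(=O)C(C)C)c1`, 226 nM
compound 3, `COC(=O)/C=C/c1cccc(N(Cc2ccc(-c3ccc(N(C)C)cc3)cc2)C(=O)C(C)C)c1`, 57 nM

In an assay on isolated protein with Bile acid receptor (Homo sapiens) as the target (on this read-out lower numbers stand for an effect already at smaller amounts and higher numbers for an effect only at larger amounts of compound), compound 3 gives the lowest of the three numbers, with compound 1 nearest and compound 2 furthest. Both steps leading to compound 3 were beyond the scatter but modest: a 2.1-fold lower number from compound 1 to compound 3 (0.32 log units; beyond the scatter) and a 4.0-fold lower number from compound 2 to compound 3 (0.60 log units; beyond the scatter).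

Compound 4, `COC(=O)/C=C/c1cccc(N(Cc2ccc(/C=C/c3cccc(Cl)c3)cc2)C(=O)C(C)C)c1`, is not yet measured. It differs from compound 3 in one place: 2-(3-chlorophenyl)ethenyl in place of 4-(dimethylamino)phenyl on an aromatic carbon. The change sits on an aromatic carbon of a six-membered aromatic ring of carbon only, para to a large group. Within the data shown here, no measured step exchanges the whole aryl group for an ethenyl-linked aryl, so the three steps bear on it only indirectly. The step from compound 1 to compound 3 shows that the dimethylamino group lowered the number, and that group now leaves. The step from compound 2 to compound 3 shows that a chlorine-bearing aryl gave a higher number than compound 3, and a chlorine-bearing aryl now enters. Taken together, an increase in number is expected for compound 4 relative to compound 3: a 2.8-fold higher number from compound 3 to compound 4 (0.45 log units; beyond the scatter).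

Compound 4 is therefore estimated at 160 nM, with an expected range from 50 nM to 500 nM.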

Compound 4, half-maximal effective concentration: 164 nM
The estimate for compound 4 lay 1.0-fold (0.01 log units) below the measured number; low and high end bracket the measured number.
By their numbers in this assay, from the lowest: compound 3; then compounds 1, 4 and 2 (each within the scatter of the next).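

The result shows that this position, on an aromatic carbon para to a large group, also tolerates a 2-(3-chlorophenyl)ethenyl group, with a double bond outside the aromatic rings, in place of a directly attached aryl: in this assay, exchanging it for 4-(dimethylamino)phenyl gives a 2.9-fold higher number from compound 3 to compound 4 (0.46 log units; beyond the scatter) and remains a modest step. Against the two other directly attached aryl groups, the ethenyl-linked group cannot be told apart, with 5-chloro-2-methoxyphenyl replaced in a 1.4-fold lower number from compound 2 to compound 4 (0.14 log units; within the scatter) and 4-methylphenyl replaced in a 1.4-fold higher number from compound 1 to compound 4 (0.14 log units; within the scatter) as the two comparisons. Nothing at hand explains why the number differs from that of compound 3. The compounds shown leave open whether the ethenyl link or the chlorine on the ring accounts for the step, as no ethenyl-linked ring without chlorine or with dimethylamino appears among them. They also leave open how a carboxylic acid in place of the methyl ester, or an amine on the ethenyl-linked ring, would read in this assay on this shared core.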